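The compounds below may be only part of what the source reports. "The series", "measured", "known", "first", "only" and "open" are said of these compounds alone.

Measured so far:
- compound 1, `O=S(=O)(NC1CCN(S(=O)(=O)c2ccccc2)CC1)c1cc(S(=O)(=O)c2ccccc2)ccc1C(F)(F)F`: 25000 nM
- compound 2, `CC(C)(C)OC(=O)N1CCC(CC(=O)N2CCC(NS(=O)(=O)c3cc(S(=O)(=O)c4ccccc4)ccc3C(F)(F)F)CC2)CC1`: 12500 nM

Compound 1 holds the highest of the two numbers in a physicochemical assay for solubility (on this read-out lower numbers stand for lower solubility and higher numbers for higher solubility), but its nearest neighbour, compound 2, sits within the scatter of it, so the two values cannot be ordered. For the measured compounds named here, no step between measured compounds is known here, so nothing about the effect of any single structural change has yet been seen.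

Compound 3, `O=C([C@H]1CCNC1)N1CCC(NS(=O)(=O)c2cc(S(=O)(=O)c3ccccc3)ccc2C(F)(F)F)CC1`, is not yet measured. It differs from compound 1 in one place: (pyrrolidin-3-yl)carbonyl in place of phenylsulfonyl on an amine nitrogen in a ring. The group that leaves has no hydrogen-bond donor; the group that enters brings one hydrogen-bond donor and fewer heavy atoms.

Without any measured step to lean on, the expectation for this change rests on the two values alone and on the change as counted. The step of a 4.0-fold higher number from compound 1 to compound 3 (0.60 log units; beyond the scatter) is expected to be an increase beyond the scatter. Compound 3 is estimated to give 100000 nM in this assay, within a range from 25000 nM to 400000 nM.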

Compound 3, solubility: 25000 nM
The estimate for compound 3 lay 4.0-fold (0.60 log units) above the measured number; the measured number falls inside the stated range.
By their numbers in this assay, from the lowest: compounds 2, 1 and 3 (each within the scatter of the next).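

In this assay, for the compounds shown here, the swap of phenylsulfonyl for (pyrrolidin-3-yl)carbonyl on an amine nitrogen in a ring gives no change at the digits printed from compound 1 to compound 3 (within the scatter) and this is the first comparison here between compounds that differ in one place. It shows that at this position a six-membered aromatic ring of carbon only can leave, and a five-membered non-aromatic ring with a hydrogen-bond donor can enter, without the read-out moving beyond the usual scatter of repeated measurements. Nothing measured here bears on why the number holds steady across so different a pair of groups.

This single step cannot say which part of the entering group matters, or whether the ring, the carbonyl or the ring nitrogen could be changed on its own with the same outcome. A simple acetyl group or a carboxylic acid on a short chain, placed on the same ring nitrogen of the shared core, would test whether this position tolerates groups of other kinds just as evenly.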